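Swapping an aryl group on a hydrazone-linked series

A few compounds are considered here, and "the series" means these few. Any claim that something is new, unique, unknown or untested is made for them only; others in the source may bear on it.

Of the compounds shown here, three that share one core have so far been tested in a functional assay on MGC-803 cells (Homo sapiens) for antiproliferative activity, read by MTT assay, with a stated time of 72 h; on this read-out lower numbers stand for stronger inhibition and higher numbers for weaker inhibition. Compound 1, with structure `CCCSc1nc(N/N=C/c2ccccc2Cl)c2nnn(Cc3ccccc3)c2n1`, gives 10900 nM in this assay. Compound 2, with structure `CCCSc1nc(N/N=C(\C)c2ccccc2O)c2nnn(Cc3ccccc3Cl)c2n1`, gives 35000 nM, and compound 3, with structure `CCCSc1nc(N/N=C/c2cc(OC)c(OC)c(OC)c2)c2nnn(Cc3ccccc3)c2n1`, gives 9410 nM. Among these three numbers compound 1 sits second highest: its value and that of compound 3 lie within the scatter of each other, so no order can be drawn between them, while the value of compound 2 lies beyond the scatter above it. All three act only weakly against these cells.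

Compound 4, with structure `CCCSc1nc(N/N=C/c2cccnc2)c2nnn(Cc3ccccc3)c2n1`, has not yet been measured. It differs from compound 1 in one place: pyridin-3-yl in place of 2-chlorophenyl on a carbon with a double bond to nitrogen. Without a measured step of this kind in the series, only a modest change is expected, and the step from compound 1 to compound 4 in this assay is estimated as a 1.4-fold higher number from compound 1 to compound 4 (0.14 log units; within the scatter), toward slightly weaker inhibition. The expected value for compound 4 is therefore 15000 nM, within a range from 6000 nM to 40000 nM.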

Compound 4, half-maximal inhibitory concentration: 38100 nM
Compound 4: middle estimate off by 2.5-fold (0.40 log units), on the low side; low and high end bracket the measured number.
By their numbers in this assay, from the lowest: compounds 3 and 1 (each within the scatter of the next); then compounds 2 and 4 (each within the scatter of the next).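

For the compounds shown here, this is the first measured step at this place, on a carbon with a double bond to nitrogen, and it shows that activity in this assay depends on the ring held there: pyridin-3-yl in place of 2-chlorophenyl brings a 3.5-fold higher number from compound 1 to compound 4 (0.54 log units; beyond the scatter) and so moves toward weaker inhibition. The swap removes the chlorine and adds a ring nitrogen, which counts as a hydrogen-bond acceptor, so this single step cannot separate the loss of one from the gain of the other. Nothing measured here explains the rise in the number.

A plain phenyl group, with neither chlorine nor ring nitrogen, could help to separate those two changes. As far as these compounds go, whether a ring carrying an amine, such as 4-aminophenyl, would be tolerated at this place remains open.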